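The source may hold more compounds than are shown below. What is called first, only, known or untested is meant among the compounds shown, and "the series" means these compounds.

Measured compounds:
compound 1, `C=CCOc1nc(N)nc2c1ncn2/C=C1/CC1(CO)CO`, in an ADME assay on MOLT-3 cells (Homo sapiens) for cytotoxicity, with a stated time of 7 days (a lower number here means that less compound is tolerated, a higher number that more compound is tolerated), compound 1 gives > 20000 nM, which is a limit of the assay rather than a number.
compound 2, `Nc1nc(NC2CC2)c2ncn(/C=C3/CC3(CO)CO)c2n1`, in this assay compound 2 gives > 20000 nM, again a limit of the assay.
compound 3, `Nc1nc(NC2CCCCC2)c2ncn(/C=C3/CC3(CO)CO)c2n1`, in this assay compound 3 gives "not determined" (no result reported), so no result was reported for it.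

The step that the two limits leave unreadable from compound 1 to compound 2, cyclopropylamino in place of allyloxy on an aromatic carbon, cannot be read, since both values sit at the limit of > 20000 nM in this assay, at which 2 of the 3 values shown sit. Among the compounds with values here, compound 3 thus stands without a number of its own; the only measured compounds sharing its core both lie at the limit.

Compound 4, `CCCCNc1nc(N)nc2c1ncn2/C=C1/CC1(CO)CO`, differs from compound 3 by butyl in place of cyclohexyl on a nitrogen on an aromatic ring. Within the data shown here, no measured step bears directly on this change, and no step among the measured compounds is readable in size, so no direction can be drawn. Compound 4 is therefore expected to behave as compounds 1 and 2 do and to be tolerated up to the limit, with an estimate of 30000 nM and a range from 15000 nM to 100000 nM.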

Compound 4, half-maximal cytotoxic concentration: > 20000 nM
Compound 4: no number, only a limit; the forecaster's own chance of this, stated with the estimate: 85%; the middle value lies beyond the limit too.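

In this assay compound 4 ends, like compound 1 and compound 2, at a limit rather than a number, so no step among these three compounds can be read: the limit of > 20000 nM in this assay, at which 3 of the 4 values shown sit. The compounds shown leave open which group at this place, if any, would bring a measurable cytotoxic concentration.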